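A few compounds are considered here, and "the series" means these few. Any claim that something is new, unique, unknown or untested is made for them only; others in the source may bear on it.

Working notes on the series. Compound 1 `Cc1ccc(-c2nc3ccccc3n2CC(=O)N2CCCC2)nc1` carries ((pyrrolidin-1-yl)carbonyl)methyl on an aromatic nitrogen; in a functional assay on the whole organism with Rattus norvegicus as the target, read by paw edema, with a stated time of 3 h, at a dose of 100 mg/kg by the oral route (a higher number here means more inhibition at the dose given (going by the name of the read-out), a lower number less inhibition), compound 1 gives 14%. Compound 2 `CCc1ccc(-c2nc3ccccc3n2-c2ccccc2)nc1` carries phenyl on that nitrogen and ethyl in place of methyl; in this assay compound 2 gives 12%. For the measured compounds named here, compound 2 stands together with compound 1: the two values lie within the scatter of each other, so no order between them can be read, and no step between measured compounds is available to lean on.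

Compound 3 `CCc1ccc(-c2nc3ccccc3n2CC(=O)N2CCCC2)nc1` is not yet measured. Its difference from compound 2: ((pyrrolidin-1-yl)carbonyl)methyl in place of phenyl on an aromatic nitrogen. Compound 3 thus carries the same group on an aromatic nitrogen as compound 1, together with the ethyl of compound 2. Given that compound 1 with that group gives 14%, nothing beyond the scatter is expected in this assay. The expected step is a number 2 percentage points higher from compound 2 to compound 3 (within the scatter). Compound 3 is estimated at 14% in this assay, with a range from 4% to 26%.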

Compound 3, a percentage reported as inhibition, in the whole organism at one dose (the size of the read-out at that dose, not a potency): -5%
The estimate for compound 3 lay 19 percentage points above the measured number; measured number below the stated range.
By their numbers in this assay, from the lowest: compound 3; then compounds 2 and 1 (each within the scatter of the next).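

In this assay, the first readable steps show that both places count: ((pyrrolidin-1-yl)carbonyl)methyl in place of phenyl on the aromatic nitrogen gives a number 17 percentage points lower from compound 2 to compound 3 (beyond the scatter), so with the ethyl present, these two nitrogen groups are not interchangeable. The smaller change, methyl in place of hydrogen on a saturated chain carbon bound to an aromatic carbon, gives a number 19 percentage points lower from compound 1 to compound 3 (beyond the scatter), so with ((pyrrolidin-1-yl)carbonyl)methyl on the nitrogen, even this small extension separates ethyl from methyl. No measurement among the data bears on the reason for either step.

The compounds shown leave open whether a longer chain such as propyl in place of the ethyl would continue this trend. They also leave open how an open-chain amide such as dimethylaminocarbonylmethyl or a carboxylic acid on the nitrogen would read alongside the ethyl.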